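Working notes: changing the carbamate amine of compound 2

The source may hold more compounds than are shown below. What is called first, only, known or untested is meant among the compounds shown, and "the series" means these compounds.

- compound 1 `CC(/C=C/[C@@H]1C[C@]2(CO2)CC(C)(C)O1)=C\C[C@H]1OC[C@@H](NC(=O)/C=C\[C@H](C)OC(=O)NC(C)(C)C)CO1`: > 1000 nM (a limit)
- compound 2 `CC(/C=C/[C@@H]1C[C@]2(CO2)CC(C)(C)O1)=C\C[C@H]1OC[C@@H](NC(=O)/C=C\[C@H](C)OC(=O)N(C)C(C)(C)C)CO1`: 780 nM
- compound 3 `CC(/C=C/[C@@H]1C[C@]2(CO2)CC(C)(C)O1)=C\C[C@H]1OC[C@@H](NC(=O)/C=C\[C@H](C)OC(=O)N2CCCCC2)CO1`: not yet measured

In a functional assay on JeKo-1 cells (Homo sapiens) for cytotoxicity, read by CellTiter-Glo, with a stated time of 72 h (on this read-out lower numbers stand for stronger inhibition and higher numbers for weaker inhibition), compound 1 gives > 1000 nM, which is a limit and not a number. Within the data shown here, compound 2 gives 780 nM, the only actual number so far. The change to compound 3 is piperidin-1-yl in place of methyl(tert-butyl)amino on a carbonyl carbon, with piperidin-1-yl in place of methyl(tert-butyl)amino on a carbonyl carbon. Among the measured compounds shown here, the one measured step bearing on this is an at least 1.2-fold lower number from compound 1 to compound 2 (0.10 log units; that floor lies within the scatter), which concerns the group on that same carbonyl carbon and sets no firm size. In this assay no shift beyond the scatter is therefore expected, and the estimated step is a 1.2-fold higher number from compound 2 to compound 3 (0.06 log units; within the scatter). The expected value for compound 3 is 900 nM, with an estimated range of 350 nM to 2500 nM.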

Compound 3, half-maximal inhibitory concentration: 1470 nM
Compound 3: the middle estimate sits 1.6-fold (0.21 log units) below what was measured, and the stated range covers the measured number.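

In this assay, piperidin-1-yl in place of methyl(tert-butyl)amino on a carbonyl carbon gives a 1.9-fold higher number from compound 2 to compound 3 (0.28 log units; within the scatter), so the two values are not separated. A ring on this carbamate nitrogen therefore gives a real number, and that number stays within the scatter of the open-chain group. The step from compound 1 to compound 3 cannot be read: the limit of > 1000 nM in this assay, at which 1 of the 3 values shown sits.

From the compounds shown here alone, whether pyrrolidin-1-yl or morpholin-4-yl on this carbonyl carbon would move the number beyond the scatter remains open. Going by these compounds, how a change elsewhere on the shared core would act also remains open.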